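The compounds below may be only part of what the source reports. "The series", "measured", "known", "first", "only" and "open" are said of these compounds alone.

Measured so far in a functional assay (Homo sapiens) for inhibition; on this read-out higher numbers stand for weaker inhibition and lower numbers for stronger inhibition
compound 1 `CSc1cccc(CSc2nc(-c3ccc(F)cc3)c(-c3ccncc3)[nH]2)c1` at 550 nM
compound 2 `C[S+]([O-])c1ccc(CSc2nc(-c3ccccc3)c(-c3ccncc3)[nH]2)cc1` at 840 nM

These two numbers lie within the scatter of each other, so compound 1 does not stand apart from compound 2 on the present data. Compound 3 `Oc1ccccc1CSc1nc(-c2ccc(F)cc2)c(-c2ccncc2)[nH]1` has yet to be measured. For the measured compounds named here, it keeps the core of compound 1 and carries 2-hydroxyphenyl in place of 3-(methylsulfanyl)phenyl on a saturated chain carbon bound to a sulfur, with the counted difference 2-hydroxyphenyl in place of 3-(methylsulfanyl)phenyl on a saturated chain carbon bound to a sulfur as the only change. Going by the values given here, no measured pair isolates this replacement, so the data give no direction for it. In this assay no step beyond the scatter is expected for now. The estimated 1.1-fold lower number from compound 1 to compound 3 (0.04 log units; within the scatter) is therefore small. For compound 3 the expected value is 500 nM with a range of 130 nM to 1800 nM on the current evidence.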

Compound 3, half-maximal inhibitory concentration: 440 nM
The estimate for compound 3 lay 1.1-fold (0.06 log units) above the measured number, and the stated range covers the measured number.
By their numbers in this assay, from the lowest: compounds 3, 1 and 2 (each within the scatter of the next).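

In this assay, for the compounds shown here, the exchange of 3-(methylsulfanyl)phenyl for 2-hydroxyphenyl on a saturated chain carbon bound to a sulfur gives a 1.3-fold lower number from compound 1 to compound 3 (0.10 log units; within the scatter) and is the first single-place comparison. At this position, a group with a hydrogen-bond donor and a group with none therefore give numbers that cannot be told apart on this read-out. No accompanying measurement bears on why this exchange leaves the numbers within the scatter.

The exchange alters both the substituent and its place on the ring, so the separate contribution of each remains unresolved. Plain benzyl, 3-hydroxybenzyl and a benzyl group carrying a carboxylic acid or an amine would show whether this position stays this flat across a wider range of groups.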